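The source may hold more compounds than are shown below. What is called first, only, known or untested is meant among the compounds shown, and "the series" means these compounds.

Compound 1, `C#CCSc1nc(Nc2ccccc2)c2ccncc2n1`: in a functional assay on PC-3 cells (Homo sapiens) for inhibition, read by MTT assay, with a stated time of 72 h (a lower number here means a stronger inhibitor, a higher number a weaker inhibitor), it is reported as > 80000 nM, a limit of the assay rather than a number.
Compound 2, `C#CCSc1nc(Nc2cccc(OC)c2)c2ccncc2n1`: 17100 nM.
Compound 3, `CCSc1nc(Nc2cccc(OC)c2)c2ccncc2n1`: 7150 nM.

Among the three numbers shown, compound 3 gives the lowest in this assay. Its nearest neighbour is compound 2, and the change between them is a 2.4-fold lower number from compound 2 to compound 3 (0.38 log units; beyond the scatter). Compound 1 sits at a limit of the assay, (the limit of > 80000 nM in this assay, at which 1 of the 3 values shown sits), so only a bound is known for it. The change from compound 1 to compound 2 is therefore an at least 4.6-fold lower number from compound 1 to compound 2 (0.67 log units; beyond the scatter).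

Compound 4, `CCCSc1nc(Nc2cccc(OC)c2)c2ccncc2n1`, has not yet been measured. Compared with compound 3 the difference is methyl in place of hydrogen on a saturated chain carbon, two bonds along the chain from a sulfur. Of the two measured steps, only a 2.4-fold lower number from compound 2 to compound 3 (0.38 log units; beyond the scatter) concerns the chain bound to the sulfur, and it swapped the end of that chain rather than lengthening it; the step from compound 1 to compound 2 lies on the aromatic ring and says nothing about this chain. The evidence is therefore thin. The expected step in this assay is a 1.3-fold lower number from compound 3 to compound 4 (0.11 log units; within the scatter), most likely within the scatter, with no firm direction. Compound 4 is estimated at 5500 nM, with a range from 2000 nM to 16000 nM.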

Compound 4, half-maximal inhibitory concentration: 15300 nM
Compound 4: middle estimate off by 2.8-fold (0.44 log units), on the low side; low and high end bracket the measured number.
By their numbers in this assay, from the lowest: compound 3; then compounds 4 and 2 (each within the scatter of the next). At a limit, above all of these: compound 1.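

Adding one methyl on a saturated chain carbon, two bonds along the chain from a sulfur, turns ethylsulfanyl into propylsulfanyl and gives the first direct reading of chain length at this position in this assay: the step is modest but beyond the scatter (a 2.1-fold higher number from compound 3 to compound 4 (0.33 log units; beyond the scatter)), so the longer chain does not improve on compound 3. Compound 4 also shows that replacing the ethynyl end of compound 2 with a saturated end is not enough on its own to change the number (a 1.1-fold lower number from compound 2 to compound 4 (0.05 log units; within the scatter)), even though the swap to the shorter methyl end gave a change beyond the scatter, so the effect of that swap depends on the chain it ends. No measurement shown explains why the extra methyl raises the number.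

With so few chains compared, a single step cannot show whether the number keeps rising with a longer chain such as butylsulfanyl, or whether a shorter methylsulfanyl would go lower still. From the compounds shown here alone, it also remains open how this position would respond to a branched isopropyl group or to a chain ending in an amine or a carboxylic acid.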